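The source may hold more compounds than are shown below. What is called first, only, known or untested is meant among the compounds shown, and "the series" means these compounds.

Measured so far in a functional assay on the whole organism for inhibition, with Rattus norvegicus as the target, at a dose of 3 mg/kg by the oral route; on this read-out higher numbers stand for a stronger effect at the one dose given and lower numbers for a weaker effect:

compound 1 `Cc1cccc(C(=O)Nc2nn[nH]n2)n1`: 46%
compound 2 `CNc1ccc(-c2cc(C)cc(C(=O)Nc3nn[nH]n3)n2)cc1`: 89%
compound 3 `Cc1ccc(C)c(C(=O)Nc2nn[nH]n2)n1`: 65%

Compound 1 stands lowest of the three numbers in this assay. Its nearest neighbour is compound 3, reached by a single change, methyl in place of hydrogen on an aromatic carbon, which gives a number 19 percentage points higher from compound 1 to compound 3 (beyond the scatter). For the measured compounds named here, compound 2 lies furthest away; no single-change step connects it to compound 1, so the two values are simply set side by side, with compound 2 at 89% against compound 1 at 46%.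

The unmeasured compound 4 `CCCCOc1cccc(C(=O)Nc2nn[nH]n2)n1` differs from compound 1 as follows: butoxy in place of methyl on an aromatic carbon. Going by the values given here, no measured step exchanges one substituent for another at that place; the only step from compound 1, the one to compound 3, adds a methyl where hydrogen stood and was modest in size. That bears on compound 4 only loosely, since here a larger group replaces the methyl rather than hydrogen. A step of comparable, modest size is therefore expected, most likely upward, but the direction is not secured by any measured pair.

For compound 4 the expected value in this assay is 55%, with a range from 30% to 80%, an expected step of a number 9 percentage points higher from compound 1 to compound 4 (within the scatter).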

Compound 4, a percentage reported as inhibition, in the whole organism at one dose (the size of the read-out at that dose, not a potency): 18%
The estimate for compound 4 lay 37 percentage points above the measured number; measured number outside the range, below it.
By their numbers in this assay, from the lowest: compound 4; then compound 1; then compound 3; then compound 2.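

In this assay the aromatic carbon next to the ring nitrogen, which holds the methyl of compound 1, does not tolerate every replacement: butoxy in place of methyl gives a number 28 percentage points lower from compound 1 to compound 4 (beyond the scatter). For the compounds shown here, this is the first downward step, as the only earlier step, a number 19 percentage points higher from compound 1 to compound 3 (beyond the scatter), went upward and lay at a different aromatic carbon, so it said nothing about exchanging the methyl at this place. Nothing measured in hand accounts for the drop, and no cause can be assigned to it.

The compounds shown leave open whether the drop goes with the oxygen that butoxy brings or with the length of the chain; a methoxy group and a plain butyl chain at the same carbon would separate the two. Also open, as far as these compounds go, is how this carbon responds to groups of another kind, such as an amine or a carboxylic acid, and whether any replacement for the methyl there raises the read-out rather than lowers it.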